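Nitro-substituted benzyl sulfide in a triazolopyrimidine series

A few compounds are considered here, and "the series" means these few. Any claim that something is new, unique, unknown or untested is made for them only; others in the source may bear on it.

Measured compounds in a functional assay on BGC-823 cells (Homo sapiens) for inhibition, read by MTT assay, with a stated time of 72 h; a lower number here means a stronger inhibitor, a higher number a weaker inhibitor:
- compound 1 `CCCSc1nc2nc(C)cc(N3CC[C@@H](C)[C@@H](N(C)c4ncnc5[nH]ccc45)C3)n2n1` gives 51200 nM
- compound 2 `Cc1cc(N2CC[C@@H](C)[C@@H](N(C)c3ncnc4[nH]ccc34)C2)n2nc(SCc3ccc(C(F)(F)F)cc3)nc2n1` gives 23300 nM
- compound 3 `Cc1cc(N2CC[C@@H](C)[C@@H](N(C)c3ncnc4[nH]ccc34)C2)n2nc(SCCc3ccccc3)nc2n1` gives 28000 nM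

Compound 3 has the second highest number of the three. Its nearest neighbour is compound 2, and the step of a 1.2-fold higher number from compound 2 to compound 3 (0.08 log units; within the scatter) lies within the scatter; the step of a 1.8-fold lower number from compound 1 to compound 3 (0.26 log units; within the scatter) lies within the scatter as well, so compound 3 cannot be ordered against either of them.

Compound 4 `Cc1cc(N2CC[C@@H](C)[C@@H](N(C)c3ncnc4[nH]ccc34)C2)n2nc(SCc3ccc([N+](=O)[O-])cc3)nc2n1` differs from compound 3 in one place: 4-nitrophenyl in place of benzyl on a saturated chain carbon bound to a sulfur. The step that bears most directly on this change is a 1.2-fold higher number from compound 2 to compound 3 (0.08 log units; within the scatter), where one substituent on the same saturated chain carbon was exchanged for another with no shift beyond the scatter. The step of a 2.2-fold lower number from compound 1 to compound 2 (0.34 log units; beyond the scatter) was modest but did cross the scatter. Taken together, these steps suggest that the nitro-bearing aryl group in compound 4 should land close to compound 3, with no step beyond the scatter expected, a 1.2-fold lower number from compound 3 to compound 4 (0.07 log units; within the scatter).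

Compound 4 is therefore estimated at 24000 nM in this assay, with a range from 12000 nM to 48000 nM.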

Compound 4, half-maximal inhibitory concentration: 59600 nM
Compound 4: the middle estimate sits 2.5-fold (0.40 log units) below what was measured, and the stated range ends below it.
By their numbers in this assay, from the lowest: compounds 2, 3, 1 and 4 (each within the scatter of the next, the first and the last beyond it).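

Going by these compounds alone, the aryl group on a saturated chain carbon bound to a sulfur proved less interchangeable than the earlier compounds suggested: nitro in place of trifluoromethyl on an aromatic carbon gave a 2.6-fold higher number from compound 2 to compound 4 (0.41 log units; beyond the scatter), and 4-nitrophenyl in place of benzyl gave a 2.1-fold higher number from compound 3 to compound 4 (0.33 log units; beyond the scatter), both modest but beyond the scatter in this assay. The aryl group therefore did not carry the same result in every case, as 4-nitrophenyl in place of ethyl gave a 1.2-fold higher number from compound 1 to compound 4 (0.07 log units; within the scatter), whereas 4-(trifluoromethyl)phenyl in that place had crossed the scatter. Nothing available explains these steps.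

The compounds shown leave open how other groups on that aromatic carbon, such as a nitrile, a methoxy or an amine, would read in this assay. They also leave open how an unsubstituted phenyl on the saturated chain carbon would compare with compound 2 and compound 4.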